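The source may report more compounds than this note shows. Statements on the series, on what has been measured and on what is new or still open speak of the compounds shown alone.

Compound 1 `COc1ccccc1/C=N/Nc1nc2ccccc2nc1Cc1ccccc1` is measured in an assay on isolated protein for inhibition of Amine oxidase [flavin-containing] A (Homo sapiens), read by spectrophotometry (a lower number here means a stronger inhibitor, a higher number a weaker inhibitor), where compound 1 gives 83 nM. Among the three numbers measured, this is the second highest. Compound 2 `COc1ccc(/C(C)=N/Nc2nc3ccccc3nc2Cc2ccccc2)cc1` gives 89 nM, a value that lies within the scatter of that of compound 1, so no order between the two can be read. Compound 3 `C/C(=N\Nc1nc2ccccc2nc1Cc1ccccc1)c1ccc(O)cc1` gives 2.8 nM, far lower than compound 1.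

The next compound, compound 4 `O=[N+]([O-])c1ccc(/C=N/Nc2nc3ccccc3nc2Cc2ccccc2)cc1`, differs from compound 1 in one place: 4-nitrophenyl in place of 2-methoxyphenyl on a carbon with a double bond to nitrogen. Within the data shown here, the only measured single-change step, a 32-fold lower number from compound 2 to compound 3 (1.50 log units; beyond the scatter), concerns a different change on the aryl ring, hydrogen in place of methyl on an oxygen, and shows that a change on this ring can move this assay a great deal. Among the measured compounds shown here, no measured step exchanges a methoxyphenyl for a nitrophenyl, so the direction is uncertain. Compound 4 is therefore expected near compound 1, with a 1.1-fold higher number from compound 1 to compound 4 (0.04 log units; within the scatter) as a tentative step and a wide range: compound 4 is estimated at 90 nM, between 20 nM and 400 nM.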

Compound 4, half-maximal inhibitory concentration: 8.8 nM
Compound 4: middle estimate off by 10-fold (1.01 log units), on the high side, outside the stated range (below it).
By their numbers in this assay, from the lowest: compound 3; then compound 4; then compounds 1 and 2 (each within the scatter of the next).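

In this assay, the exchange of 2-methoxyphenyl for 4-nitrophenyl on the carbon with a double bond to nitrogen gives a 9.4-fold lower number from compound 1 to compound 4 (0.97 log units; beyond the scatter). The earlier step showed only that altering the oxygen substituent of a methoxyphenyl group could move this number; this step shows that a ring without any methoxy or hydroxy group can also give a markedly lower number than compound 1 at this position. Nothing at hand accounts for the size of this step.

The step replaces the whole group, so the identity of the substituent and its place on the ring change together, and the compounds shown cannot separate the two. They also leave open how an amine or a carboxylic acid in place of the nitro group would read in this assay.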